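Small Methyl Where a Benzyl Once Stood

This account rests on a few compounds, and the source may have more. Where it says the series, first, only, none or still open, it means among the compounds named here.

compound 1 `CN(Cc1ccccc1)S(=O)(=O)c1ccc(NC(=O)NCc2ccncc2)cc1` gives 23 nM in an assay on isolated protein for activation of Nicotinamide phosphoribosyltransferase (Homo sapiens); a lower number here means that less compound is needed, a higher number that more compound is needed for the effect
compound 2 `CNS(=O)(=O)c1ccc(NC(=O)NCc2ccncc2)cc1` gives 3230 nM

Compound 2 has the highest number of the two measured compounds. For the measured compounds named here, the single measured step, a 140-fold higher number from compound 1 to compound 2 (2.15 log units; beyond the scatter), is large and concerns the same sulfonamide nitrogen. Compound 3 `CN(C)S(=O)(=O)c1ccc(NC(=O)NCc2ccncc2)cc1` carries methyl in place of hydrogen on a sulfonamide nitrogen. That step bears directly on this change, but a methyl is not a benzyl, so only a modest part of that step is expected to be reversed. Compound 3 is therefore expected to give about 1500 nM, between 400 nM and 5000 nM. The expected step, a 2.2-fold lower number from compound 2 to compound 3 (0.33 log units; beyond the scatter), is a lower number.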

Compound 3, half-maximal effective concentration: 3110 nM
The estimate for compound 3 lay 2.1-fold (0.32 log units) below the measured number; measured number inside the range.
By their numbers in this assay, from the lowest: compound 1; then compounds 3 and 2 (each within the scatter of the next).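

Putting a methyl on the sulfonamide nitrogen leaves the number unchanged within the scatter (a 1.0-fold lower number from compound 2 to compound 3 (0.02 log units; within the scatter)), so simply filling this nitrogen with a second group does not recover the low number of compound 1. With a methyl in both compounds' place of comparison gone, the phenyl on the saturated chain carbon alone marks the large gap (a 140-fold higher number from compound 1 to compound 3 (2.13 log units; beyond the scatter)). Nothing available explains this gap.

Open, going by these compounds, is whether a propyl chain could stand in for the benzyl. Also open, on these data alone, is whether a cyclohexylmethyl group could do so.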